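Sulfonamide aryl variation on the shared core

A few compounds are considered here, and "the series" means these few. Any claim that something is new, unique, unknown or untested is made for them only; others in the source may bear on it.

Measured so far in a functional assay on SMMC-7721 cells (Homo sapiens) for antiproliferative activity, read by MTT assay, with a stated time of 72 h; on this read-out higher numbers stand for weaker inhibition and lower numbers for stronger inhibition:
- compound 1 `CN(C(=O)c1ccc(F)cc1)c1ccc2[nH]c(-c3n[nH]c4ccccc34)cc2n1` gives 9150 nM
- compound 2 `CN(C(=O)c1ccco1)c1ccc2[nH]c(-c3n[nH]c4ccccc34)cc2n1` gives 28200 nM
- compound 3 `CN(c1ccc2[nH]c(-c3n[nH]c4ccccc34)cc2n1)S(=O)(=O)c1ccccc1` gives 12000 nM

Compound 3 has the second highest of the three numbers in this assay; its nearest neighbour is compound 1 a 1.3-fold higher number from compound 1 to compound 3 (0.12 log units; within the scatter), its furthest compound 2 a 2.4-fold lower number from compound 2 to compound 3 (0.37 log units; beyond the scatter). Compound 4 `COc1ccc(S(=O)(=O)N(C)c2ccc3[nH]c(-c4n[nH]c5ccccc45)cc3n2)c(OC)c1` is not yet measured. It differs from compound 3 only at the sulfonyl sulfur: 2,4-dimethoxyphenyl in place of phenyl on a sulfonyl sulfur.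

For the measured compounds named here, none of the measured steps changes a substituent on the aryl group attached to the sulfonyl sulfur. Going by the values given here, the only step that alters an aryl group while leaving the rest intact sits on a carbonyl carbon, a 3.1-fold higher number from compound 1 to compound 2 (0.49 log units; beyond the scatter), and it was modest. The steps that exchange the whole group on the ring nitrogen, from compound 1 to compound 3 and from compound 2 to compound 3, were at most modest. On this basis a step of compound 4 relative to compound 3 beyond the usual scatter in this assay is not expected in either direction.

For compound 4 the expected value in this assay is 10000 nM, with a range from 3000 nM to 35000 nM, which means an expected step of a 1.2-fold lower number from compound 3 to compound 4 (0.08 log units; within the scatter).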

Compound 4, half-maximal inhibitory concentration: 10800 nM
Compound 4: middle estimate off by 1.1-fold (0.03 log units), on the low side; low and high end bracket the measured number.
By their numbers in this assay, from the lowest: compounds 1, 4 and 3 (each within the scatter of the next); then compound 2.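

In this assay, for the compounds shown here, the first substituent change on the aryl group attached to the sulfonyl sulfur, 2,4-dimethoxyphenyl in place of phenyl, gives a 1.1-fold lower number from compound 3 to compound 4 (0.05 log units; within the scatter). The group on the sulfonyl sulfur can therefore grow from 6 to 10 heavy atoms and from 0 to 2 hydrogen-bond acceptors without a shift beyond the scatter in this antiproliferative read-out, so this substitution pattern neither gains nor loses measurable activity on these cells. No independent data are at hand that bear on this result.

With a single substituted aryl group in the sulfonamide set, the compounds shown cannot separate the contribution of each methoxy group, and it remains possible that the two have opposing contributions that cancel or that neither has any effect. From the compounds shown here alone, it also remains open whether the flat response holds for an amine or a carboxylic acid on the aryl group, or for a methyl group or a longer alkyl chain in place of the aryl group on the sulfonyl sulfur.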